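Halogen swap on the aryl tail: compound 3 to compound 4

This account rests on a few compounds, and the source may have more. Where it says the series, first, only, none or still open, it means among the compounds named here.

The series shares one core, varied only on the aryl group at the end of the chain that carries the sulfur. Compound 1 `C#CCNC1CCc2c(SCCc3ccc(Br)cc3)cccc21` gives 1250 nM in an ADME assay on isolated protein for inhibition of Amine oxidase [flavin-containing] B (Homo sapiens); a higher number here means a weaker inhibitor, a lower number a stronger inhibitor. Compound 2 `C#CCNC1CCc2c(SCCc3cccc(C(F)(F)F)c3)cccc21` gives 280 nM in this assay, and compound 3 `C#CCNC1CCc2c(SCCc3ccc(Cl)cc3)cccc21` gives 920 nM. Compound 3 thus sits second highest of the three numbers, next to compound 1 and apart from compound 2, whose number is lower beyond the scatter.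

Compound 4 `C#CCNC1CCc2c(SCCc3cccc(F)c3)cccc21` is unmeasured and differs from compound 3 by 3-fluorophenyl in place of 4-chlorophenyl on a saturated chain carbon, two bonds along the chain from a sulfur. Among the measured compounds shown here, the one measured step of the same kind, a change of halogen at the same position, is a 1.4-fold lower number from compound 1 to compound 3 (0.13 log units; within the scatter), within the scatter. For the measured compounds named here, the shift to a 3-substituted ring has no direct step; only compound 2, also 3-substituted, shows a lower number than compound 3. For compound 4 the expected step is therefore a 1.5-fold lower number from compound 3 to compound 4 (0.19 log units; within the scatter), a modest lowering that may not exceed the scatter. Compound 4 is estimated at 600 nM, within 250 nM to 1500 nM.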

Compound 4, half-maximal inhibitory concentration: 7810 nM
The estimate for compound 4 lay 13-fold (1.11 log units) below the measured number; measured number above the stated range.
By their numbers in this assay, from the lowest: compound 2; then compounds 3 and 1 (each within the scatter of the next); then compound 4.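

In this assay this position proves far less tolerant than the bromo-to-chloro swap suggested: 3-fluorophenyl in place of 4-chlorophenyl gives an 8.5-fold higher number from compound 3 to compound 4 (0.93 log units; beyond the scatter), and in place of 4-bromophenyl it gives a 6.2-fold higher number from compound 1 to compound 4 (0.80 log units; beyond the scatter). A 3-substituted ring does not by itself keep the number low, since fluoro in place of trifluoromethyl on that ring gives a 28-fold higher number from compound 2 to compound 4 (1.45 log units; beyond the scatter), the largest of these steps. No evidence available here accounts for these steps.

The steps from the 4-substituted rings change the halogen and its ring placement together, so the share of each remains unresolved. Also open, on these data alone, is how a methoxy group or a nitrile on the aryl ring, or a longer chain to that ring, would compare with the trifluoromethyl group of compound 2.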